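Working notes: methoxy removal in a porcupine inhibitor series

A few compounds are considered here, and "the series" means these few. Any claim that something is new, unique, unknown or untested is made for them only; others in the source may bear on it.

Measured compounds:
- Compound 1, `O=C(CNC(=O)c1nn(-c2ccccc2)c(=O)c2ccccc12)Nc1nc2ccc(Cl)cc2s1`, gives 30 nM in an assay on L cells for inhibition of Protein-serine O-palmitoleoyltransferase porcupine (Mus musculus), read by reporter gene assay, with a stated time of 24 h; on this read-out lower numbers stand for an effect already at smaller amounts and higher numbers for an effect only at larger amounts of compound.
- Compound 2, `COc1ccc(-n2nc(C(=O)NCC(=O)Nc3nc4ccc(Cl)cc4s3)c3ccccc3c2=O)cc1`, gives 15 nM in this assay.
- Compound 3, `COc1ccc(-n2c(SCC(=O)Nc3nc4ccc(OC)cc4s3)nc3c(c2=O)SCC3)cc1`, gives 120 nM in this assay.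

Compounds 1 and 2 share one core and differ in a single place: hydrogen in place of methoxy on an aromatic carbon. The step of a 2.0-fold higher number from compound 2 to compound 1 (0.30 log units; within the scatter) is within the scatter, so the two values are not distinguished here.

Compound 3 has a different core; the difference between the cores of compound 3 and compound 2 is not broken down here. Compound 3 carries the highest of the three numbers, beyond the scatter against both compound 1 and compound 2.

Compound 4, `COc1ccc2nc(NC(=O)CSc3nc4c(c(=O)n3-c3ccccc3)SCC4)sc2c1`, is not yet measured. It relates to compound 3 by hydrogen in place of methoxy on an aromatic carbon, the same change that leads from compound 2 to compound 1, and the two places agree word for word. The change occurs twice among the compounds shown, once measured. Within the data shown here, with only one measured instance, the expectation for compound 4 rests on that step and on the value of compound 3.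

Among the measured compounds shown here, the step from compound 3 to compound 4 is estimated as a 1.8-fold higher number from compound 3 to compound 4 (0.26 log units; within the scatter), of a size similar to the measured step, because a 2.0-fold higher number from compound 2 to compound 1 (0.30 log units; within the scatter) is the only guide available. For the measured compounds named here, compound 4 is accordingly expected to give about 220 nM in this assay, with a range from 80 nM to 600 nM reflecting the scatter and the single precedent.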

Compound 4, half-maximal effective concentration: 40 nM
The estimate for compound 4 lay 5.5-fold (0.74 log units) above the measured number; measured number outside the range, below it.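

In this assay the change from 4-methoxyphenyl to phenyl on the core of compound 3 gives a clear step (a 3.0-fold lower number from compound 3 to compound 4 (0.48 log units; beyond the scatter)) and does not repeat what it did on the other core, so in this series the effect of this change cannot be carried from one core to the other as a fixed amount: the same change on two cores in this assay, a 2.0-fold higher number (0.30 log units; within the scatter) from compound 2 to compound 1 and a 3.0-fold lower number (0.48 log units; beyond the scatter) from compound 3 to compound 4, 6.0-fold (0.78 log units) apart, beyond the scatter of two such steps. The result on the core of compound 1 is itself within the scatter, so the contrast is between a step beyond the scatter and one that cannot be told from no change, and it does not establish two opposite effects. With one pair on each core, the data do not show which part of the two cores accounts for the gap, nor whether the step seen on the core of compound 3 would hold for other members of that core.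

The compounds shown leave open how the same place responds to groups other than methoxy and hydrogen, for example an amine, a carboxylic acid or a longer chain such as ethoxy. Also open, going by these compounds, is whether the remaining methoxy on compound 4 can be changed without losing the gain, since only the 4-methoxyphenyl to phenyl change has been read here.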